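Repositioning chlorine and trifluoromethyl on the urea aryl group

The source may report more compounds than this note shows. Statements on the series, on what has been measured and on what is new or still open speak of the compounds shown alone.

The measured compounds and their values in a functional assay on A-375 cells (Homo sapiens) for inhibition, read by MTT assay, with a stated time of 120 h; a higher number here means a weaker inhibitor, a lower number a stronger inhibitor:
compound 1 `CC1CN(C(=O)c2ccc(-c3ccc(NC(=O)Nc4ccc(Cl)c(C(F)(F)F)c4)cc3)cc2)CC(C)O1`: > 50000 nM, a limit of the assay.
compound 2 `CNC(=O)C#Cc1ccc(NC(=O)Nc2ccc(Cl)c(C(F)(F)F)c2)cc1`: > 50000 nM, also a limit.
compound 3 `CC(NC(=O)c1ccc(-c2ccc(NC(=O)Nc3ccc(Cl)c(C(F)(F)F)c3)cc2)cc1)c1ccccc1`: 12800 nM.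

Compound 1 stands at the limit of > 50000 nM in this assay, at which 2 of the 3 values shown sit, so for compound 1 only a limit is known and no number. For the measured compounds named here, the one measured step that starts from compound 1 is an at least 3.9-fold lower number from compound 1 to compound 3 (0.59 log units; beyond the scatter), a change at the carbonyl carbon on the far side of the shared core and not at the urea aryl group.

Compound 4 `CC1CN(C(=O)c2ccc(-c3ccc(NC(=O)Nc4cc(C(F)(F)F)ccc4Cl)cc3)cc2)CC(C)O1` differs from compound 1 by 2-chloro-5-(trifluoromethyl)phenyl in place of 4-chloro-3-(trifluoromethyl)phenyl on an amide-type nitrogen. No measured pair changes this aryl group, so nothing shown bears directly on the step. With compound 1 at a limit, the expectation rests on compound 1 alone; compound 4 is expected to stay near that limit, and the expected step is a number no higher from compound 1 to compound 4 (the limit leaves the size open). The estimate for compound 4 in this assay is 50000 nM, with a range from 10000 nM to 200000 nM.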

Compound 4, half-maximal inhibitory concentration: > 50000 nM
Compound 4: a limit, no number; the forecaster's own chance of this, stated with the estimate: 70%; the middle value sits exactly at the limit.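

In this assay compound 4 gives > 50000 nM as a limit of the assay, not a number. For the compounds shown here, compound 1 also stands at a limit, so no step from compound 1 to compound 4 can be read. The compounds shown leave open whether 2-chloro-5-(trifluoromethyl)phenyl in place of 4-chloro-3-(trifluoromethyl)phenyl changes the number in this assay at all.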